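The compounds below may be only part of what the source reports. "The series", "measured", "known", "first", "only" and "open" are said of these compounds alone.

Compound 1 `Cc1nc(-c2ccc(C(F)(F)F)cc2)sc1CNc1ccc(CCC(=O)O)cc1` — 67.6 nM
Compound 2 `Cc1nc(-c2ccc(C(F)(F)F)cc2)sc1CNc1ccc(/C=C/C(=O)O)cc1` — 36.3 nM
Compound 3 `O=C(O)COc1ccc(NCc2cccc(Oc3ccccc3)c2)cc1` — 2040 nM

In a functional assay on CHO cells for agonist activity at Free fatty acid receptor 1 (Homo sapiens) (a higher number here means that more compound is needed for the effect, a lower number that less compound is needed), compound 1 gives 67.6 nM, compound 2 gives 36.3 nM, and compound 3 gives 2040 nM, the highest number of the three. Compound 4 `CC(C)NC(=O)CCc1ccc(NCc2cccc(Oc3ccccc3)c2)cc1` differs from compound 3 by 2-(isopropylcarbamoyl)ethyl in place of carboxymethoxy on an aromatic carbon. Within the data shown here, the only measured step, a 1.9-fold lower number from compound 1 to compound 2 (0.27 log units; within the scatter), alters the chain that carries the carboxylic acid while keeping the acid itself; no measured step removes the acid, as this change does, so the measured data offer little guidance. Because compound 3 already gives 2040 nM and the carboxylic acid common to all measured compounds is lost here, a higher number is expected, with wide uncertainty. Compound 4 is estimated at 6000 nM, most likely between 1500 nM and 30000 nM, which would mean an expected 2.9-fold higher number from compound 3 to compound 4 (0.47 log units; beyond the scatter).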

Compound 4, half-maximal effective concentration: 39.8 nM
Beside the measured number, compound 4's estimate is 150-fold (2.18 log units) above it; measured number below the stated range.
By their numbers in this assay, from the lowest: compounds 2, 4 and 1 (each within the scatter of the next); then compound 3.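

In this assay, putting 2-(isopropylcarbamoyl)ethyl in place of carboxymethoxy at this position gives a 51-fold lower number from compound 3 to compound 4 (1.71 log units; beyond the scatter) and is a large change. Compound 4 carries no carboxylic acid, so on this core the acid is not needed for a low number. No measurement here explains the size of this step. The change swaps the whole group at once, so the compounds shown do not separate the contributions of the amide, its isopropyl end and the chain. From the compounds shown here alone, a methyl amide or a longer chain at this position remains open.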